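The source may report more compounds than this note shows. Statements on the series, on what has been measured and on what is new or still open speak of the compounds shown alone.

The measured compounds and their values in a functional assay on A549 cells (Homo sapiens) for cytotoxicity, read by MTT assay, with a stated time of 72 h (on this read-out higher numbers stand for weaker inhibition and lower numbers for stronger inhibition), are:

Compound 1, `O=Cc1cn(Cc2ccc(Cl)cc2)c2ccccc12`: compound 1 gives 2480 nM
Compound 2, `CCN(CC)Cc1ccc2nc(NC(=O)N/N=C/c3cn(Cc4ccccc4Cl)c4ccccc34)sc2c1`: compound 2 gives 1390 nM
Compound 3, `Cc1ccc(Cn2cc(/C=N/NC(=O)Nc3nc4ccc(CN(C)C)cc4s3)c3ccccc32)cc1`: compound 3 gives 1600 nM

On these three numbers compound 3 stands second highest. Its nearest neighbour is compound 2, and its furthest is compound 1, but both of those gaps lie within the usual scatter of repeated measurements, so the three compounds cannot be placed in any order of strength on the evidence shown. Going by the values given here, no pair of measured compounds differs in a single place, so no measured step is available to guide the next comparison.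

Compound 4, `Cc1ccc(Cn2cc(/C=N/NC(=O)Nc3nc4ccc(CN5CCC(C)CC5)cc4s3)c3ccccc32)cc1`, has not yet been measured in this assay. It differs from compound 3 in one place: 4-methylpiperidin-1-yl in place of dimethylamino on a saturated chain carbon bound to an aromatic carbon. Among the compounds with values here, nothing among the measured compounds shows what such a change does here, so the expectation is a step no larger than the scatter, in either direction. The step from compound 3 to compound 4 that this estimate means is a 1.1-fold lower number from compound 3 to compound 4 (0.06 log units; within the scatter). Compound 4 is therefore expected to give about 1400 nM, with a likely range from 500 nM to 4000 nM.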

Compound 4, half-maximal inhibitory concentration: 2180 nM
Compound 4: middle estimate off by 1.6-fold (0.19 log units), on the low side, and the stated range covers the measured number.
By their numbers in this assay, from the lowest: compounds 2, 3, 4 and 1 (each within the scatter of the next).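

Going by these compounds alone, this is the first measured step at this place: in this assay, 4-methylpiperidin-1-yl in place of dimethylamino on a saturated chain carbon bound to an aromatic carbon gives a 1.4-fold higher number from compound 3 to compound 4 (0.13 log units; within the scatter) and so cannot be told apart from repeat measurement. The number therefore shows no readable response when the group grows from 3 heavy atoms with no ring to 7 heavy atoms with one six-membered non-aromatic ring. Nothing shown speaks to the reason for this result.

On these data alone, it remains open whether a morpholin-4-yl or piperazin-1-yl group on the same saturated chain carbon would give a step beyond the scatter. The same question stands for a carboxylic acid there, or for a longer chain between the amine nitrogen and the aromatic carbon.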